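A few compounds are considered here, and "the series" means these few. Any claim that something is new, unique, unknown or untested is made for them only; others in the source may bear on it.

Working notes on the series. The shared core carries a variable substituent on a carbonyl carbon. Compound 1 `CC(C)(C)c1ccc(C(=O)N2CCC3(CC2)C(=O)N(CC(=O)N2CCN(S(C)(=O)=O)CC2)CN3c2ccccc2)cc1` gives 19000 nM in an assay on HEK293 cells for displacement of a labelled ligand from NPC1-like intracellular cholesterol transporter 1 (Homo sapiens); on this read-out higher numbers stand for weaker inhibition and lower numbers for stronger inhibition. Compound 2 `CC(C)(C)c1ccc(C(=O)N2CCC3(CC2)C(=O)N(CC(=O)NCCN)CN3c2ccccc2)cc1` gives 7000 nM. Compound 3 `CC(C)(C)c1ccc(C(=O)N2CCC3(CC2)C(=O)N(CC(=O)NCCCN)CN3c2ccccc2)cc1` gives 4200 nM, the lowest of the three numbers; its gap to compound 2 lies within the scatter, so the two cannot be ordered, while its gap to compound 1 lies beyond it.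

The measured steps: a 2.7-fold lower number from compound 1 to compound 2 (0.43 log units; beyond the scatter); a 4.5-fold lower number from compound 1 to compound 3 (0.66 log units; beyond the scatter); and a 1.7-fold lower number from compound 2 to compound 3 (0.22 log units; within the scatter).

Compound 4 `CCOC(=O)C1CCN(C(=O)CN2CN(c3ccccc3)C3(CCN(C(=O)c4ccc(C(C)(C)C)cc4)CC3)C2=O)CC1` is not yet measured. The change from compound 3: 4-(ethoxycarbonyl)piperidin-1-yl in place of (3-aminopropyl)amino on a carbonyl carbon. This runs opposite to the steps from compound 1, which swapped a 4-(methylsulfonyl)piperazin-1-yl for an aminoalkylamino chain and gave lower numbers both times; compound 4 returns to one six-membered non-aromatic ring with 1 hetero atom on the carbonyl carbon, though as 4-(ethoxycarbonyl)piperidin-1-yl rather than 4-(methylsulfonyl)piperazin-1-yl. Only compound 1 supports an expectation for such a ring, so the expected step is a rise of roughly the size of those two steps, with wide uncertainty: compound 4 is expected to show a 3.1-fold higher number from compound 3 to compound 4 (0.49 log units; beyond the scatter) in this assay. The estimate for compound 4 is 13000 nM, with a range from 5000 nM to 35000 nM.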

Compound 4, half-maximal inhibitory concentration: 3100 nM
Beside the measured number, compound 4's estimate is 4.2-fold (0.62 log units) above it; measured number below the stated range.
By their numbers in this assay, from the lowest: compounds 4, 3 and 2 (each within the scatter of the next, the first and the last beyond it); then compound 1.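

In this assay, the step of a 1.4-fold lower number from compound 3 to compound 4 (0.13 log units; within the scatter) shows that a six-membered non-aromatic ring on this carbonyl carbon does not by itself go with a high number, and that the aminoalkylamino chains are not needed to reach the low end of the series: 4-(ethoxycarbonyl)piperidin-1-yl has 0 hydrogen-bond donors and (3-aminopropyl)amino has 2, yet the two cannot be ordered. The same replacement gives a 2.3-fold lower number from compound 2 to compound 4 (0.35 log units; beyond the scatter) and, against the other ring-bearing compound, a 6.1-fold lower number from compound 1 to compound 4 (0.79 log units; beyond the scatter) with a change of ring substituent and ring type, so the high number of compound 1 belongs to 4-(methylsulfonyl)piperazin-1-yl specifically and not to rings at this place in general. The compounds shown give no measurement that accounts for these differences between groups.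

From the compounds shown here alone, what the ethoxycarbonyl group itself contributes remains open, since the ring is not compared here with an unsubstituted piperidin-1-yl or with the corresponding carboxylic acid in place of the ethyl ester. Also open, going by these compounds, is whether a longer chain carrying a terminal amine, or a piperidine ring carrying an amine, would move the number beyond the scatter of the present low group.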